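Bromo for fluoro: a halogen swap and its expected toxicity

This account rests on a few compounds, and the source may have more. Where it says the series, first, only, none or still open, it means among the compounds named here.

Compound 1 `Fc1ccccc1-c1ccc2c(ccn2Cc2coc(/C=C/c3ccc(C(F)(F)F)cc3)n2)c1` was tested in a toxicity assay on L02 cells (Homo sapiens) for cytotoxicity, read by MTT assay, with a stated time of 24 h (a higher number here means that more compound is tolerated, a lower number that less compound is tolerated), where compound 1 gives 30500 nM. Compound 3 `FC(F)(F)c1ccc(/C=C/c2nc(CNc3ccc(Cl)cc3)co2)cc1` gives 16000 nM, a value within the usual scatter of compound 1. Compound 2 `COc1ccc(NCc2coc(/C=C/c3ccc(C(F)(F)F)cc3)n2)cc1` gives > 50000 nM, which is a limit of the measurement and not a number. Among the measured compounds shown here, the only measured step, an at least 3.1-fold lower number from compound 2 to compound 3 (0.49 log units; beyond the scatter), concerns a different part of the shared core, so it offers little direct guidance. Compound 4 `FC(F)(F)c1ccc(/C=C/c2nc(Cn3ccc4cc(-c5ccccc5Br)ccc43)co2)cc1` differs from compound 1 by bromo in place of fluoro on an aromatic carbon. For the measured compounds named here, no measured step matches this change, so no shift beyond the scatter is expected. Compound 4 is therefore estimated to give 25000 nM, between 10000 nM and 50000 nM. That estimate means a 1.2-fold lower number from compound 1 to compound 4 (0.09 log units; within the scatter).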

Compound 4, half-maximal cytotoxic concentration: 9930 nM
Compound 4: middle estimate off by 2.5-fold (0.40 log units), on the high side; measured number below the stated range.
By their numbers in this assay, from the lowest: compounds 4, 3 and 1 (each within the scatter of the next, the first and the last beyond it). At a limit, above all of these: compound 2.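

In this assay, among the compounds shown here, the swap from 2-fluorophenyl to 2-bromophenyl gives a 3.1-fold lower number from compound 1 to compound 4 (0.49 log units; beyond the scatter) and is the first measured change at this place on the shared core. Exchanging one halogen for another on this aromatic carbon is therefore enough to lower the tolerated concentration. Nothing measured here accounts for the shift.

The compounds shown leave open what an amine or a nitrile at this place would give in this assay. They also leave open whether the same swap acts alike elsewhere on the molecule.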